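Adding a Second Methoxy Group to Compound 1

This account rests on a few compounds, and the source may have more. Where it says the series, first, only, none or still open, it means among the compounds named here.

Compound 1 `COc1ccc(/C=C/C(=O)c2c(OC)cc(O)c(CC=C(C)C)c2O)cc1` is tested in a functional assay on A549 cells (Homo sapiens) for inhibition, read by MTT assay, with a stated time of 72 h (a lower number here means a stronger inhibitor, a higher number a weaker inhibitor), where compound 1 gives 38000 nM. Within the data shown here, of the two numbers measured so far this is the highest, so compound 1 is the weaker of the pair. Its neighbour, compound 2 `COc1ccccc1/C=C/C(=O)c1c(OC)cc(O)c(CC=C(C)C)c1O`, gives 12500 nM in this assay; the step of a 3.0-fold lower number from compound 1 to compound 2 (0.48 log units; beyond the scatter) comes from putting 2-methoxyphenyl in place of 4-methoxyphenyl, not from adding a methoxy group. Compound 3 `COc1ccc(/C=C/C(=O)c2c(OC)cc(O)c(CC=C(C)C)c2O)cc1OC` keeps compound 1 unchanged except for one difference: methoxy in place of hydrogen on an aromatic carbon. Among the measured compounds shown here, no measured step adds a group to this ring, so the only guide is that one change on this ring shifted the number modestly. A small shift in either direction, within or near the scatter, is therefore expected, and compound 3 is estimated at 30000 nM, spanning 10000 nM to 90000 nM, which means an expected step of a 1.3-fold lower number from compound 1 to compound 3 (0.10 log units; within the scatter).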

Compound 3, half-maximal inhibitory concentration: 15700 nM
For compound 3 the middle estimate is 1.9-fold (0.28 log units) above the measured one; measured number inside the range.
By their numbers in this assay, from the lowest: compounds 2 and 3 (each within the scatter of the next); then compound 1.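

Putting methoxy in place of hydrogen on an aromatic carbon, ortho to a methoxy group and meta to a large group, gives a 2.4-fold lower number from compound 1 to compound 3 (0.38 log units; beyond the scatter) in this assay and so makes the compound a stronger inhibitor. Among these compounds, the earlier step only moved the single methoxy group to another place on the ring, whereas this one shows that an extra group can be added while the original methoxy stays, and that the number falls by more than the usual scatter. Nothing measured here explains why this added methoxy has that effect.

From the compounds shown here alone, it remains open whether methoxy itself matters at this position, or whether a hydroxyl group, a fluorine atom, an amine or a longer chain such as ethoxy would do the same. It is also unclear whether the new methoxy would lower the number without the original methoxy beside it in the structure.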